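Replacing a sulfur bridge with a hydroxylated carbon bridge

The compounds below may be only part of what the source reports. "The series", "measured", "known", "first", "only" and "open" are said of these compounds alone.

Measured so far:
compound 1, `CC(C)CN(CC(C)C)S(=O)(=O)c1ccc(NC(=O)C(C)(O)C(F)(F)F)cc1`, > 30000 nM
compound 2, `CC(O)(C(=O)Nc1ccc(Sc2ccccc2)cc1)C(F)(F)F`, > 30000 nM
compound 3, `CC(O)(C(=O)Nc1ccc(S(=O)(=O)N2CCOCC2)cc1)C(F)(F)F`, 5850 nM

All three compounds share the same core and were tested in an assay on a protein complex (Cavia porcellus) with sulfonylurea receptors; K-ATP channels (Homo sapiens) as the target; on this read-out higher numbers stand for weaker inhibition and lower numbers for stronger inhibition. Compound 1 reaches only the limit of the assay, > 30000 nM. Compound 2 likewise reaches only the limit, > 30000 nM. Compound 3 gives a number, 5850 nM. Within the data shown here, the one step between measured compounds that differ in a single place is an at least 5.1-fold lower number from compound 1 to compound 3 (0.70 log units; beyond the scatter).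

Compound 2 therefore stands at the limit of > 30000 nM in this assay, at which 2 of the 3 values shown sit; it is one of two compounds with only a limit, and the only one with a sulfur bridge to a second ring.

The unmeasured compound 4, `CC(O)(C(=O)Nc1ccc([C@H](O)c2ccccc2)cc1)C(F)(F)F`, differs from compound 2 by hydroxy(phenyl)methyl in place of phenylsulfanyl on an aromatic carbon.

Among the measured compounds shown here, the single measured step concerns other groups on the sulfonyl sulfur, not the bridge between the two rings, so it does not bear directly on this change. With compound 2 at a limit, any expectation can only be loose. The step is therefore expected to be an at least 1.5-fold lower number from compound 2 to compound 4 (0.17 log units; that floor lies within the scatter). Compound 4 is estimated to give 20000 nM in this assay, between 5000 nM and 60000 nM.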

Compound 4, half-maximal inhibitory concentration: > 30000 nM
Compound 4 ended at the assay's limit (the forecaster's own chance of this, stated with the estimate: 50%); middle value at least 1.5-fold (0.17 log units) away from the limit.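

Compound 2 and compound 4 both end at a limit of the assay rather than at a number, so the step between them cannot be read: the limit of > 30000 nM in this assay, at which 3 of the 4 values shown sit. The compounds shown leave open how far each lies past that limit, and whether hydroxy(phenyl)methyl in place of phenylsulfanyl changes the read-out at all.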